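Dropping the ethyl on the core of compound 1

A few compounds are considered here, and "the series" means these few. Any claim that something is new, unique, unknown or untested is made for them only; others in the source may bear on it.

Compound 1 `CCc1nc(-c2ccc(Cl)cc2Cl)c(CC)nc1NC(CC)CC` gives 0.283 h in an in vitro ADME assay on microsomes (Homo sapiens) for metabolic stability (a lower number here means that the compound disappears faster, a higher number that the compound lasts longer), the lowest of the two numbers; its nearest neighbour is compound 2 `CCc1nc(-c2ccc(Cl)cc2Cl)c(OC)nc1NC(CC)CC`, which gives 0.7 h. Among the measured compounds shown here, the one measured step, a 2.5-fold higher number from compound 1 to compound 2 (0.39 log units; beyond the scatter), changes the same ethyl that is now taken away. Compound 3 `CCc1nc(NC(CC)CC)cnc1-c1ccc(Cl)cc1Cl` differs from compound 1 by hydrogen in place of ethyl on an aromatic carbon. For the measured compounds named here, with only that one step to go on, a modest rise is expected, near or somewhat below the methoxy step. Compound 3 is therefore estimated at 0.45 h, with a range of 0.2 h to 1 h, an expected step of a 1.6-fold higher number from compound 1 to compound 3 (0.20 log units; within the scatter).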

Compound 3, half-life: 0.467 h
The estimate for compound 3 lay 1.0-fold (0.02 log units) below the measured number, and the stated range covers the measured number.
By their numbers in this assay, from the lowest: compounds 1, 3 and 2 (each within the scatter of the next, the first and the last beyond it).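

In this assay, hydrogen in place of ethyl on this aromatic carbon gives a 1.7-fold higher number from compound 1 to compound 3 (0.22 log units; within the scatter), so the two substituents cannot be told apart here in this read-out. Of the two changes at this position, only methoxy, with a 2.5-fold higher number from compound 1 to compound 2 (0.39 log units; beyond the scatter), lies beyond the scatter. Nothing measured on these compounds accounts for either step.

The compounds shown leave open how an amine, a hydroxyl or a longer chain such as propyl would read on this aromatic carbon. Also open, going by these compounds, is whether the methoxy step would hold with another group in place of the (pentan-3-yl)amino group.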